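Thiophene hydrazone series: cytotoxicity working notes

The source may report more compounds than this note shows. Statements on the series, on what has been measured and on what is new or still open speak of the compounds shown alone.

In a toxicity assay (L929 cells) for cytotoxicity, with Mus musculus as the target, read by MTT assay, with a stated time of 48 h (a higher number here means that more compound is tolerated, a lower number that less compound is tolerated), compound 1 `NNC(=O)c1nn(-c2ccccc2)c(=O)c2c1cnn2-c1ccccc1` gives "not determined" (no result reported), which is no result. In this assay compound 3 `O=C(N/N=C/c1cccs1)c1nn(-c2ccc(Cl)cc2)c(=O)c2c1cnn2-c1ccccc1` gives "not determined" (no result reported), likewise no result. In this assay, for the measured compounds named here, compound 2 `O=C(N/N=C/c1cccs1)c1nn(-c2ccccc2)c(=O)c2c1cnn2-c1ccccc1` gives 186000 nM, the only number in the set, so it stands alone with nothing to rank it against. Compound 4 `O=C(N/N=C/c1ccc(-c2cccs2)s1)c1nn(-c2ccccc2)c(=O)c2c1cnn2-c1ccccc1` is the next entry and differs from compound 2 by thiophen-2-yl in place of hydrogen on an aromatic carbon. Going by the values given here, no step between measured compounds exists, so any expectation rests on the single value of compound 2 alone. The step expected in this assay is a 1.6-fold lower number from compound 2 to compound 4 (0.19 log units; within the scatter), judged small, downward, and not clearly beyond the scatter. For compound 4 the estimate in this assay is 120000 nM, with a range from 45000 nM to 320000 nM.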

Compound 4, half-maximal cytotoxic concentration: 77400 nM
Estimate against measurement, compound 4: 1.6-fold (0.19 log units) above; low and high end bracket the measured number.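

In this assay, for the compounds shown here, thiophen-2-yl in place of hydrogen on the aromatic carbon next to the ring sulfur gives a 2.4-fold lower number from compound 2 to compound 4 (0.38 log units; beyond the scatter), the first step that can be read. This position therefore has one measured change, which lies beyond the scatter and goes towards less compound being tolerated. Nothing available explains this shift.

Steps involving compound 1 or compound 3 cannot be read. As far as these compounds go, it remains open whether a carboxylic acid or an amine at this position would move the number in the same direction as thiophen-2-yl.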